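A few compounds are considered here, and "the series" means these few. Any claim that something is new, unique, unknown or untested is made for them only; others in the source may bear on it.

Working notes on one series with a shared core, read in a functional assay on Jurkat cells (Homo sapiens); on this read-out lower numbers stand for stronger inhibition and higher numbers for weaker inhibition. Compound 1 `CC(C)[C@H](NC(=O)COc1cccc2ccccc12)C(=O)N[C@@H](CC(=O)O)C(=O)COc1cccc2ccccc12` gives > 100000 nM, which is a limit of the assay and not a number. Compound 2 `CC(C)[C@H](NC(=O)COc1cccc2ccccc12)C(=O)N[C@@H](CC(=O)O)C(=O)COc1c(F)cccc1F` gives 2040 nM, and compound 3 `CC(C)[C@H](NC(=O)COc1cccc2ccccc12)C(=O)N[C@@H](CC(=O)O)C(=O)COc1c(F)c(F)cc(F)c1F` gives 4500 nM. Among the compounds with values here, compound 3 therefore has the higher of the two actual numbers so far.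

Compound 4 `CC(C)[C@H](NC(=O)COc1cccc2ccccc12)C(=O)N[C@@H](CC(=O)O)C(=O)COc1ccc([N+](=O)[O-])cc1F` is the next entry, with 2-fluoro-4-nitrophenyl in place of 2,3,5,6-tetrafluorophenyl on an oxygen on a saturated carbon. Both groups are a six-membered aromatic ring of carbon only.

Within the data shown here, the closest precedent is a 2.2-fold higher number from compound 2 to compound 3 (0.34 log units; beyond the scatter), a modest change that also swaps one fluorine-bearing phenyl group for another. The much larger steps, an at least 49-fold lower number from compound 1 to compound 2 (1.69 log units; beyond the scatter) and an at least 22-fold lower number from compound 1 to compound 3 (1.34 log units; beyond the scatter), both remove naphthalen-1-yl, a change absent here, so they bear on this comparison only weakly. Among the measured compounds shown here, the precedent gives no firm direction, and a nitro-bearing group has no measured precedent. A step of modest size at most is expected in this assay, most likely none beyond the scatter.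

The estimated change is a 1.3-fold lower number from compound 3 to compound 4 (0.11 log units; within the scatter). For compound 4 the expected value is 3500 nM, with an estimated range from 1200 nM to 12000 nM.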

Compound 4, half-maximal inhibitory concentration: 30300 nM
For compound 4 the middle estimate is 8.7-fold (0.94 log units) below the measured one; measured number above the stated range.
By their numbers in this assay, from the lowest: compound 2; then compound 3; then compound 4. At a limit, above all of these: compound 1.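

In this assay the swap of one fluorine-bearing phenyl group for another on an oxygen on a saturated carbon is not always a small one, with 2-fluoro-4-nitrophenyl giving a 6.7-fold higher number from compound 3 to compound 4 (0.83 log units; beyond the scatter) and a 15-fold higher number from compound 2 to compound 4 (1.17 log units; beyond the scatter) on the same core. The earlier pair had shown only a 2.2-fold higher number from compound 2 to compound 3 (0.34 log units; beyond the scatter) for such a swap, so a fluorine-bearing phenyl group at this place does not by itself keep the number near those of compound 2 and compound 3. Compound 1 is a limit and not a number, and the change from naphthalen-1-yl to 2-fluoro-4-nitrophenyl can be read only as a bound, an at least 3.3-fold lower number from compound 1 to compound 4 (0.51 log units; beyond the scatter) and no exact size: the limit of > 100000 nM in this assay, at which 1 of the 4 values shown sits.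

Compound 4 carries the nitro group and has fewer fluorines than compound 3, so the shown compounds do not separate the part played by the nitro group from the part played by the fluorines that leave. A 2-fluorophenyl group, or an amine or a nitrile in place of the nitro group on the same ring, would bear on that question, and no measured property here explains the step.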